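The source may hold more compounds than are shown below. What is called first, only, known or untested is meant among the compounds shown, and "the series" means these compounds.

Measured compounds:
compound 1, `COc1ccc(C(=O)c2cc(OC)c(OC)c(OC)c2)cc1N`: 2100 nM
compound 2, `COc1cccc(/C=C/C(=O)Nc2cc(OC)c(OC)c(OC)c2)c1`: 3200 nM
compound 3, `C#CCOc1cccc(/C=C/C(=O)Nc2cc(C(=O)c3cc(OC)c(OC)c(OC)c3)ccc2OC)c1`: 15800 nM

All three were tested in a functional assay on DU-145 cells (Homo sapiens) for cytotoxicity, read by MTT assay, with a stated time of 72 h; on this read-out lower numbers stand for stronger inhibition and higher numbers for weaker inhibition. Compound 3 has the highest number of the three; its gap to compound 2 and its gap to compound 1 both lie beyond the scatter, so compound 3 is the weakest of the measured set. Compound 4, `COc1ccc(C(=O)c2cc(OC)c(OC)c(OC)c2)cc1NC(=O)/C=C/c1ccc(N)cc1`, has not yet been measured. It differs from compound 3 by 4-aminophenyl in place of 3-(propargyloxy)phenyl on a double-bonded chain carbon bound to a double-bonded chain carbon. Going by the values given here, no measured pair shows this change, so its size is unknown. Compound 1 and compound 2 give lower numbers than compound 3, which points weakly toward a modest decrease. Compound 4 is therefore expected to show a step of a 2.0-fold lower number from compound 3 to compound 4 (0.30 log units; within the scatter). The estimate for compound 4 in this assay is 8000 nM, with a range from 2000 nM to 30000 nM.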

Compound 4, half-maximal inhibitory concentration: 13500 nM
Compound 4: the middle estimate sits 1.7-fold (0.23 log units) below what was measured; low and high end bracket the measured number.
By their numbers in this assay, from the lowest: compounds 1 and 2 (each within the scatter of the next); then compounds 4 and 3 (each within the scatter of the next).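

In this assay, 4-aminophenyl in place of 3-(propargyloxy)phenyl on a double-bonded chain carbon bound to a double-bonded chain carbon gives a 1.2-fold lower number from compound 3 to compound 4 (0.07 log units; within the scatter), so the two groups cannot be told apart at this position. The larger effect comes from the chain itself: (2-(4-aminophenyl)ethenyl)carbonyl in place of hydrogen on a nitrogen on an aromatic ring gives a 6.4-fold higher number from compound 1 to compound 4 (0.81 log units; beyond the scatter), a weakening. Nothing measured here gives a reason for either step. On these data alone, whether acetyl on that nitrogen, or plain phenyl in place of 4-aminophenyl, would give a different number stays open.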